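Swapping the Ring on a Compound at the Assay Limit

A few compounds are considered here, and "the series" means these few. Any claim that something is new, unique, unknown or untested is made for them only; others in the source may bear on it.

Compound 1 `O=C(O)c1ccccc1-c1ccccc1C(=O)NCCCCCCCn1cc(-c2cccnc2)nn1`: > 500 nM (a limit)
Compound 2 `O=C(NCCCCCCCn1cc(-c2cccnc2)nn1)c1ccccc1-c1cccnc1`: 36.5 nM
Compound 3 `O=C(NCCCCCCCn1cc(-c2cccnc2)nn1)c1ccccc1-n1cc(CN2CCC(O)CC2)nn1`: > 10000 nM (a limit)

All three results come from an ADME assay on SH-SY5Y cells (Homo sapiens) for cytotoxicity, read by MTT assay, with a stated time of 48 h; on this read-out higher numbers stand for an effect only at larger amounts of compound and lower numbers for an effect already at smaller amounts. Compound 3 gives > 10000 nM, which is a limit of the assay and not a number.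

Compound 4 `CN1CCN(Cc2cn(-c3ccccc3C(=O)NCCCCCCCn3cc(-c4cccnc4)nn3)nn2)CC1` has not yet been measured. It differs from compound 3 in one place: 4-methylpiperazin-1-yl in place of 4-hydroxypiperidin-1-yl on a saturated chain carbon bound to an aromatic carbon. In words, this is 4-methylpiperazin-1-yl in place of 4-hydroxypiperidin-1-yl on a saturated chain carbon bound to an aromatic carbon. Both groups are six-membered non-aromatic rings with no net charge.

For the measured compounds named here, no measured step makes this swap. Going by the values given here, the only measured step is an at least 13-fold lower number from compound 1 to compound 2 (1.13 log units; beyond the scatter). That step is large, but it concerns a different change, pyridin-3-yl in place of 2-carboxyphenyl on an aromatic carbon. It shows that a single change can move the number a long way in this series, but it gives neither a size nor a direction for the ring swap. The nearest guide is therefore compound 3 itself, with its limit of > 10000 nM.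

The expected step is an at least 1.2-fold lower number from compound 3 to compound 4 (0.09 log units; that floor lies within the scatter), so no change beyond the scatter is expected. The estimate for compound 4 is 8000 nM, with an expected range from 1500 nM to 20000 nM.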

Compound 4, half-maximal effective concentration: > 10000 nM
Compound 4 gave a limit, no number; the forecaster's own chance of this, stated with the estimate: 55%; middle value at least 1.2-fold (0.09 log units) from the limit.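

Compound 3 and compound 4 both gave a limit of the assay and not a number, so no step can be read between them, because they share the same limit: the limit of > 10000 nM in this assay, at which 2 of the 4 values shown sit.

The compounds shown leave open whether 4-methylpiperazin-1-yl in place of 4-hydroxypiperidin-1-yl changes the number at all, and if so, in which direction and by how much.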